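The compounds below may be only part of what the source reports. "The series", "measured", "known", "first", "only" and "open" are said of these compounds alone.

Compound 3 `CN(Cc1ccccc1)CC1CCN(CCCc2c[nH]c3ccc(-n4cnnc4)cc23)CC1` gives the lowest number of the three in an assay on CHO cells for displacement of a labelled ligand from 5-hydroxytryptamine receptor 1D (Homo sapiens) (on this read-out higher numbers stand for weaker inhibition and lower numbers for stronger inhibition), at 0.9 nM. Compound 1 `c1ccc(CNCC2CCN(CCCc3c[nH]c4ccc(-n5cnnc5)cc34)CC2)cc1` gives 1.6 nM in this assay; the step from compound 1 to compound 3 was a 1.8-fold lower number from compound 1 to compound 3 (0.25 log units; within the scatter). Compound 2 `CN(Cc1cccs1)C1CCN(CCCc2c[nH]c3ccc(-n4cnnc4)cc23)CC1` gives 4.3 nM in this assay; the step of a 4.8-fold lower number from compound 2 to compound 3 (0.68 log units; beyond the scatter) and the step of a 2.7-fold higher number from compound 1 to compound 2 (0.43 log units; beyond the scatter) show that the aryl group and its linkage move the number modestly.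

Compound 4 `c1ccc2c(c1)CCC2NCC1CCN(CCCc2c[nH]c3ccc(-n4cnnc4)cc23)CC1` carries the change ((2,3-dihydro-1H-inden-1-yl)amino in place of benzyl(methyl)amino on a saturated chain carbon bound to a saturated ring carbon). Among the compounds with values here, the loss of methyl on the amine nitrogen mirrors compound 1, whose step to compound 3 was within the scatter; no precedent exists for the (2,3-dihydro-1H-inden-1-yl)amino group. The estimated step of a 2.2-fold higher number from compound 3 to compound 4 (0.35 log units; beyond the scatter) is therefore expected to stay within the scatter. For compound 4 the expected value in this assay is 2 nM, range 0.7 nM to 6 nM.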

Compound 4, half-maximal inhibitory concentration: 1.1 nM
Beside the measured number, compound 4's estimate is 1.8-fold (0.26 log units) above it; measured number inside the range.
By their numbers in this assay, from the lowest: compounds 3, 4 and 1 (each within the scatter of the next); then compound 2.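

In this assay, the five-membered non-aromatic ring entering with (2,3-dihydro-1H-inden-1-yl)amino is tolerated at this position: a 1.2-fold higher number from compound 3 to compound 4 (0.09 log units; within the scatter) and a 1.5-fold lower number from compound 1 to compound 4 (0.16 log units; within the scatter) both stay within the scatter, whether read against benzyl(methyl)amino or against benzyl on the amine nitrogen. With a 3.9-fold lower number from compound 2 to compound 4 (0.59 log units; beyond the scatter), the new group also stays apart from the thiophene-bearing compound 2, although that step changes both the aryl group and its linkage. No measured evidence bears on why the number holds.

Still open, on these data alone, is whether a 1,2,3,4-tetrahydronaphthalen-1-yl group, or a methyl on the amine nitrogen of the new group, would hold the number as well.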